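Paw edema inhibition from a methoxyphenyl to a chlorophenyl piperazine

The compounds below may be only part of what the source reports. "The series", "measured", "known", "first", "only" and "open" are said of these compounds alone.

Measured compounds:
Compound 1, `CC(C)Cc1ccc(C(C)c2nn(CN3CCN(c4ccc([N+](=O)[O-])cc4)CC3)c(=S)o2)cc1`: 75.1%
Compound 2, `COc1ccc(N2CCN(Cn3nc(Cc4ccc(SC)cc4)oc3=S)CC2)cc1`: 33.7%

In a functional assay on the whole organism (strain Wister albino) for inhibition, with Rattus norvegicus as the target, read by paw edema, with stated times of 30 min and 3 h, at a dose of 10 mg/kg by the oral route (on this read-out lower numbers stand for less inhibition and higher numbers for more inhibition at the one dose given (going by the name of the read-out)), compound 1 gives 75.1% and compound 2 gives 33.7%. Compound 2 thus stands lowest of the two numbers; compound 1 lies beyond the scatter above it. The two differ in more than one place, so their values are shown only side by side.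

Compound 3, `CSc1ccc(Cc2nn(CN3CCN(c4cccc(Cl)c4)CC3)c(=S)o2)cc1`, has not yet been measured in this assay. It differs from compound 2 by 3-chlorophenyl in place of 4-methoxyphenyl on an amine nitrogen in a ring. Within the data shown here, no single-point step between measured compounds exists to guide this change. He therefore expects a small step from compound 2 to compound 3, upward if at all, and likely within the scatter: a number 8.3 percentage points higher from compound 2 to compound 3 (within the scatter) is the estimated movement. For compound 3 the expected inhibition in this assay is 42%, within a range from 25% to 60%.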

Compound 3, a percentage reported as inhibition, in the whole organism at one dose (the size of the read-out at that dose, not a potency): 74.7%
For compound 3 the middle estimate is 32.7 percentage points below the measured one; measured number outside the range, above it.
By their numbers in this assay, from the lowest: compound 2; then compounds 3 and 1 (each within the scatter of the next).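

In this assay, the aromatic group on the amine nitrogen of the six-membered ring with two nitrogens turns out to matter greatly: 3-chlorophenyl in place of 4-methoxyphenyl gives a number 41 percentage points higher from compound 2 to compound 3 (beyond the scatter). Among these compounds, this is the first step that changes one place only, so this large rise can be assigned to that single exchange rather than to other differences in the molecule. No measurement shown explains why the exchange has this effect.

The change replaces the substituent on the phenyl ring and moves its location at the same time, so the compounds shown cannot separate these two changes. A 4-chlorophenyl or a 3-methoxyphenyl group at this position would keep one feature and vary the other, while an unsubstituted phenyl group would show what either substituent contributes.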